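Compound 2 to compound 3: a ring gives way

This account rests on a few compounds, and the source may have more. Where it says the series, first, only, none or still open, it means among the compounds named here.

Measured in a functional assay on SH-SY5Y cells (Homo sapiens) for cytotoxicity, read by MTT assay, with a stated time of 72 h; on this read-out higher numbers stand for weaker inhibition and lower numbers for stronger inhibition:
- compound 1 `O=C1c2c[n+]([O-])c3ccccc3c2C(=O)c2c1c1ccccc1n2Cc1cn([C@H]2O[C@H](CO)[C@@H](O)[C@H]2O)nn1`: 1340 nM
- compound 2 `CC1(C)OCC(Cn2cc(Cn3c4c(c5ccccc53)C(=O)c3c[n+]([O-])c5ccccc5c3C4=O)nn2)O1`: 230 nM

Of these two numbers, compound 2 has the lower one, so it is the stronger inhibitor on this read-out. Compound 3 `O=C1c2c[n+]([O-])c3ccccc3c2C(=O)c2c1c1ccccc1n2Cc1cn(CC(O)CO)nn1` has not been measured yet. It differs from compound 2 at one place: 1,2-dihydroxyethyl in place of 2,2-dimethyl-1,3-dioxolan-4-yl on a saturated chain carbon bound to an aromatic nitrogen. In words, 1,2-dihydroxyethyl stands in place of 2,2-dimethyl-1,3-dioxolan-4-yl on a saturated chain carbon bound to an aromatic nitrogen.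

Among the compounds with values here, only one measured step bears on this: a 5.8-fold lower number from compound 1 to compound 2 (0.77 log units; beyond the scatter). That modest step, beyond the scatter, replaced 3,4-dihydroxy-5-(hydroxymethyl)oxolan-2-yl with (2,2-dimethyl-1,3-dioxolan-4-yl)methyl. Compound 3 gives up the same dioxolane and regains hydroxy groups, so part of that step may run in reverse. The groups are not identical, and a single step is thin evidence. A rise of modest size in this assay therefore seems likely, probably smaller than the measured step. The expected step is a 2.6-fold higher number from compound 2 to compound 3 (0.42 log units; beyond the scatter). For compound 3 the estimated value is 600 nM, with an expected range of 250 nM to 1400 nM.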

Compound 3, half-maximal inhibitory concentration: > 1000 nM
Compound 3: only a limit was reported; the forecaster's own chance of this, stated with the estimate: 2%; middle value at least 1.6-fold (0.22 log units) from the limit.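

In this assay, compound 3 carries only a limit, not a measured number: the limit of > 1000 nM in this assay, at which 1 of the 3 values shown sits.

Even so, the limit is enough to show a direction: replacing 2,2-dimethyl-1,3-dioxolan-4-yl with 1,2-dihydroxyethyl gives an at least 4.3-fold higher number from compound 2 to compound 3 (0.63 log units; beyond the scatter). The earlier step exchanged the whole group on the aromatic nitrogen, whereas this one alters only the end of the chain, on a saturated chain carbon bound to an aromatic nitrogen, and the number still responds beyond the scatter. This single change removes a ring and adds 2 hydrogen-bond donors at once, so the result cannot separate the two and gives no cause for the rise.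

On these data alone, the step between compound 1 and compound 3 cannot be read, and how far the number rises from compound 2 also stays unknown. As far as these compounds go, it also remains open whether an open chain ending in a methoxy group, an amine or a carboxylic acid would give a number closer to that of compound 2 or to the limit of compound 3.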